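The source may hold more compounds than are shown below. What is called first, only, known or untested is meant among the compounds shown, and "the series" means these compounds.

Working notes on the series. Compound 1 `N#C/C(=C\c1ccc[nH]1)C(=O)NCc1ccc(Cl)c(Cl)c1`, compound 2 `COc1ccc(CNC(=O)/C(C#N)=C/c2ccc(-c3ccccc3)o2)cc1` and compound 3 `COc1ccc(CNC(=O)/C(C#N)=C/c2cccc3ccccc23)cc1` share a core and have been run in a functional assay on A-431 cells (Homo sapiens) for inhibition, read by MTT assay, with a stated time of 72 h; on this read-out higher numbers stand for weaker inhibition of growth and lower numbers for stronger inhibition of growth. For compound 1 the result is a limit of the assay, > 50000 nM; this is the limit of > 50000 nM in this assay, at which 1 of the 3 values shown sits. For compound 2 the result is likewise a limit, > 100000 nM; this is the limit of > 100000 nM in this assay, at which 1 of the 3 values shown sits. For the measured compounds named here, compound 3 is the one compound of the three with a number, giving 15000 nM in this assay, so it stands alone as the reference point. Going by the values given here, no pair of measured compounds differs in a single place, so no measured step is available.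

Compound 4 `N#C/C(=C\c1cccc2ccccc12)C(=O)NCc1ccc(Cl)c(Cl)c1`, not yet measured, follows from compound 3 by 3,4-dichlorophenyl in place of 4-methoxyphenyl on a saturated chain carbon bound to an amide-type nitrogen. Only the group on the saturated chain carbon bound to the amide-type nitrogen changes; the rest of compound 3 is kept. Compound 1 carries the same 3,4-dichlorophenyl and ends at a limit, > 50000 nM, but it differs from compound 4 elsewhere as well, so it does not fix the size of the step. The step from compound 3 to compound 4 is expected to be small, a 1.3-fold lower number from compound 3 to compound 4 (0.10 log units; within the scatter), with no clear direction beyond the scatter. Compound 4 is therefore expected to give 12000 nM in this assay, within 3000 nM to 60000 nM.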

Compound 4, concentration for 50% growth inhibition: 8000 nM
Estimate against measurement, compound 4: 1.5-fold (0.18 log units) above, within the range that was stated.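

Placing 3,4-dichlorophenyl in place of 4-methoxyphenyl on a saturated chain carbon bound to an amide-type nitrogen gives the first measured step of the series in this assay (a 1.9-fold lower number from compound 3 to compound 4 (0.27 log units; within the scatter)), so with the rest of the structure kept, this exchange of one substituted aromatic ring for another leaves the two values within the scatter of each other. Compound 1 carries the same 3,4-dichlorophenyl and stays at a limit of the assay, > 50000 nM, so that group alone does not yield a number in this series. The information at hand includes nothing that explains the size of this step.

Steps involving the limits of compound 1 and compound 2 cannot be read, so the part of the structure that keeps the other end of the molecule on scale remains unsettled. Going by these compounds, it also remains open how this assay would respond to an amine, a carboxylic acid or a longer chain on the saturated chain carbon bound to an amide-type nitrogen, in place of the substituted aromatic rings.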